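Series notes: from compound 3 to compound 4, chain extension

This account rests on a few compounds, and the source may have more. Where it says the series, first, only, none or still open, it means among the compounds named here.

Measured in an assay for displacement of a labelled ligand from DNA repair protein REV1 (Homo sapiens), read by fluorescence polarization, with a stated time of 1 h; on this read-out lower numbers stand for stronger inhibition and higher numbers for weaker inhibition:
compound 1, `CCCC1CCc2c(sc(NC(=O)C3CCN(C(C)=O)CC3)c2C(N)=O)C1`, 11900 nM
compound 2, `CCCc1cc(C(=O)OCC)c(NC(=O)C2CCN(C(C)=O)CC2)s1`, 11600 nM
compound 3, `COC(=O)c1cc(C)sc1NC(=O)C1CCN(C(C)=O)CC1`, 7400 nM

Compound 3 carries the lowest number of the three, but its gaps to compound 2 and to compound 1 both fall within the scatter, so no ranking among the three is supported; all three read as one level on this assay. Going by the values given here, no pair of measured compounds differs in a single place, so no measured step is available to calibrate the effect of changing one group.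

Compound 4, `CCc1cc(C(=O)OC)c(NC(=O)C2CCN(C(C)=O)CC2)s1`, has not yet been measured in this assay. It differs from compound 3 by methyl in place of hydrogen on a saturated chain carbon bound to an aromatic carbon. Compound 2 carries a propyl chain and an ethyl ester and sits in the same band as compound 3 and compound 1, which gives no sign that lengthening the chain moves the number; compound 2 differs from compound 3 in more than one place, however, so that comparison is only indicative. The expected step in this assay is none beyond the scatter, a 1.1-fold higher number from compound 3 to compound 4 (0.06 log units; within the scatter). Compound 4 is therefore estimated at 8500 nM, with a range from 3500 nM to 20000 nM.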

Compound 4, inhibition constant: 28800 nM
For compound 4 the middle estimate is 3.4-fold (0.53 log units) below the measured one; the measured number lies above the stated range.
By their numbers in this assay, from the lowest: compounds 3, 2 and 1 (each within the scatter of the next); then compound 4.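

In this assay, the series now has its first step in a single place: a 3.9-fold higher number from compound 3 to compound 4 (0.59 log units; beyond the scatter), for methyl in place of hydrogen on a saturated chain carbon bound to an aromatic carbon, which read one bond further out is methyl to ethyl. The position is therefore sensitive to chain length, since a change of 1 heavy atom, with no ring, no hydrogen-bond donor or acceptor and no net charge entering, moves the number towards weaker inhibition by more than the scatter, a modest step that rests on this one pair. No measurement shown here bears on the origin of this step.

Still open, from the compounds shown here alone, is whether the number keeps rising along the chain, as a butyl chain on the core of compound 3 would show, or whether a hydroxyl group or an amine on the same chain carbon reads differently from methyl. Also open, going by these compounds, is whether the step from methyl to ethyl holds when the methyl ester is replaced by an ethyl ester or a carboxylic acid, since this single pair carries the methyl ester alone.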